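This account rests on a few compounds, and the source may have more. Where it says the series, first, only, none or still open, it means among the compounds named here.

Measured compounds:
compound 1, `CC(C)(C)OC(=O)N1CCC(O[C@H]2CC[C@H](Oc3ccc(S(C)(=O)=O)cn3)CC2)CC1`: 110 nM
compound 2, `Cc1nc(O[C@H]2CC[C@H](OC3CCN(C(=O)OC(C)(C)C)CC3)CC2)ccc1C(=O)N(C)C`: 400 nM
compound 3, `C[C@@H](CF)OC(=O)N1CCC(O[C@H]2CC[C@H](Oc3cnc(S(C)(=O)=O)cn3)CC2)CC1`: 356 nM

All three numbers come from a functional assay on isolated protein for agonist activity at Glucose-dependent insulinotropic receptor (Rattus norvegicus), read by HTRF and cAMP accumulation; on this read-out lower numbers stand for an effect already at smaller amounts and higher numbers for an effect only at larger amounts of compound. Compound 3 stands second highest of the three; its nearest neighbour is compound 2, whose number lies within the scatter of it, and its furthest is compound 1, whose lower number lies beyond the scatter. Compound 4, `CC(F)Cc1nc(CN2CCC(O[C@H]3CC[C@H](Oc4cnc(S(C)(=O)=O)cn4)CC3)CC2)no1`, has not been measured. It differs from compound 3 in one place: a group of 10 heavy atoms (6 carbon, 2 nitrogen, 1 oxygen, 1 fluorine; one five-membered aromatic ring with 3 hetero atoms) in place of a group of 7 heavy atoms (4 carbon, 2 oxygen, 1 fluorine; no ring), on an amine nitrogen in a ring. Among the measured compounds shown here, no measured pair shows a change of this kind, so the size of the step cannot be read from the measured compounds. In this assay the expected step is a 1.2-fold lower number from compound 3 to compound 4 (0.07 log units; within the scatter), small and not clearly beyond the scatter in either direction. Compound 4 is estimated to give 300 nM, within 80 nM to 1200 nM.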

Compound 4, half-maximal effective concentration: 267 nM
The estimate for compound 4 lay 1.1-fold (0.05 log units) above the measured number; low and high end bracket the measured number.
By their numbers in this assay, from the lowest: compound 1; then compounds 4, 3 and 2 (each within the scatter of the next).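

Putting (5-(2-fluoropropyl)-1,2,4-oxadiazol-3-yl)methyl on the amine nitrogen gives a 1.3-fold lower number from compound 3 to compound 4 (0.12 log units; within the scatter) in this assay. This position therefore accepts a five-membered aromatic ring with 3 hetero atoms in place of a group with no ring, and the two numbers stay within the scatter of each other. Nothing available explains this result.

On these data alone, it remains open whether a plain alkyl chain or an amide on this nitrogen would read the same, and whether the fluorine in the side chain matters. As far as these compounds go, the same exchange on the core of compound 1 also remains open.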